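Halogen variation on the shared core: expectation for compound 4

The source may hold more compounds than are shown below. What is called first, only, known or untested is meant among the compounds shown, and "the series" means these compounds.

Within the data shown here, compound 3 `CC(=O)Nc1ccc(S(=O)(=O)NNc2ccc(Cl)cc2)cc1` gives 155 nM in an assay for inhibition of Indoleamine 2,3-dioxygenase 1 (Homo sapiens), read by spectrophotometry, with stated times of 1 h and 4 h (on this read-out lower numbers stand for stronger inhibition and higher numbers for weaker inhibition), the second highest of the three numbers measured so far. Compound 2 `CC(=O)Nc1ccc(S(=O)(=O)NNc2ccc(F)cc2)cc1` gives 79 nM, and a 2.0-fold higher number from compound 2 to compound 3 (0.29 log units; within the scatter). Compound 1 `CC(=O)Nc1ccc(S(=O)(=O)NNc2ccc(C(F)(F)F)cc2)cc1` gives 1610 nM; a 10-fold lower number from compound 1 to compound 3 (1.02 log units; beyond the scatter), while a 20-fold lower number from compound 1 to compound 2 (1.31 log units; beyond the scatter).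

Compound 4 `CC(=O)Nc1ccc(S(=O)(=O)NNc2ccc(Cl)c(F)c2)cc1` differs from compound 3 by fluoro in place of hydrogen on an aromatic carbon. Among the measured compounds shown here, every step measured so far exchanges one group for another on the same aromatic carbon; no step adds a second halogen to a ring that already carries one, so the change to compound 4 has no direct precedent. The nearest comparison is the exchange of fluoro and chloro, which stayed within the scatter, and the large steps arose only from removing trifluoromethyl.

On that basis, compound 4 is expected to show no step beyond the scatter, a 1.3-fold lower number from compound 3 to compound 4 (0.11 log units; within the scatter), with a slight lean toward a lower number. The estimate for compound 4 in this assay is 120 nM, with a range from 45 nM to 320 nM.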

Compound 4, half-maximal inhibitory concentration: 194 nM
For compound 4 the middle estimate is 1.6-fold (0.21 log units) below the measured one; the range from low to high includes it.
By their numbers in this assay, from the lowest: compounds 2, 3 and 4 (each within the scatter of the next, the first and the last beyond it); then compound 1.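

In this assay, fluoro in place of hydrogen, ortho to a chloro group and meta to a large group, gives a 1.3-fold higher number from compound 3 to compound 4 (0.10 log units; within the scatter). Among these compounds, this is the first step that puts a second halogen on a ring already carrying one, and it shows that this aromatic carbon can take fluoro without a step beyond the scatter, whereas the exchange of trifluoromethyl for chloro gave a 10-fold lower number from compound 1 to compound 3 (1.02 log units; beyond the scatter). Nothing available on these compounds accounts for this result.

As far as these compounds go, it remains open whether a larger group on this carbon, such as a methoxy group, an amine or a carboxylic acid, would also stay within the scatter of compound 3. From the compounds shown here alone, it is equally open whether fluoro on this carbon would give a similarly small step on a ring carrying fluoro or trifluoromethyl in place of the chloro group.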